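A few compounds are considered here, and "the series" means these few. Any claim that something is new, unique, unknown or untested is made for them only; others in the source may bear on it.

Measured compounds in a functional assay on ACHN cells (Homo sapiens) for cytotoxicity, read by MTT assay, with a stated time of 48 h; on this read-out higher numbers stand for weaker inhibition and lower numbers for stronger inhibition:
compound 1, `O=C(Nc1nc2ccc(Cl)cc2s1)c1cc(-c2ccc(F)cc2)n2nc(-c3ccccc3)cc2n1`, gives 13800 nM.
compound 2, `COc1ccc(-c2cc(C(=O)Nc3nc4ccc(Cl)cc4s3)nc3cc(-c4ccccc4)nn23)cc1`, gives 7240 nM.
compound 3, `COc1cc(-c2cc(C(=O)Nc3nc4ccc(Cl)cc4s3)nc3cc(-c4ccccc4)nn23)cc(OC)c1OC`, gives 41700 nM.

Compound 2 holds the lowest of the three numbers, but its gap to compound 1 is within the scatter a 1.9-fold lower number from compound 1 to compound 2 (0.28 log units; within the scatter), so the two are not separated; only compound 3 stands apart, a 5.8-fold higher number from compound 2 to compound 3 (0.76 log units; beyond the scatter) and a 3.0-fold higher number from compound 1 to compound 3 (0.48 log units; beyond the scatter).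

Compound 4, `COc1ccc(-c2cc(C(=O)Nc3nc4ccc(F)cc4s3)nc3cc(-c4ccccc4)nn23)cc1`, differs from compound 2 only by fluoro in place of chloro on an aromatic carbon. For the measured compounds named here, none of the measured steps touches this position: all three alter the aryl group on the shared core, not the halogen on the fused ring. Going by the values given here, no measured step therefore bears directly on this change, and nothing argues for a shift beyond the scatter in this assay . Compound 4 is expected to sit close to compound 2, with an expected step of a 1.0-fold higher number from compound 2 to compound 4 (0.02 log units; within the scatter). The estimate for compound 4 is 7500 nM, with a range from 2500 nM to 22000 nM.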

Compound 4, half-maximal inhibitory concentration: 39300 nM
Estimate against measurement, compound 4: 5.2-fold (0.72 log units) below; the measured number lies above the stated range.
By their numbers in this assay, from the lowest: compounds 2 and 1 (each within the scatter of the next); then compounds 4 and 3 (each within the scatter of the next).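

In this assay, the halogen on the benzothiazole is not a silent position: fluoro in place of chloro gives a 5.4-fold higher number from compound 2 to compound 4 (0.73 log units; beyond the scatter). For the compounds shown here, the earlier steps changed only the aryl group on the shared core, so this is the first sign that a single-atom change at this second site can move the number beyond the scatter. Nothing at hand accounts for the step.

From the compounds shown here alone, the finding rests on one pair, with 4-methoxyphenyl held fixed, so its carry-over to the 4-fluorophenyl or 3,4,5-trimethoxyphenyl compounds remains open. Going by these compounds, how bromo, methyl or an amine at this place would read also remains open.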